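The compounds below may be only part of what the source reports. "The series", "measured", "known", "first", "only" and "open" are said of these compounds alone.

Among the measured compounds shown here, compound 1, `CN(CC1=CC[C@H]2C[C@@H]1C2(C)C)Cc1ccc(-c2ccccc2)cc1`, is the only compound in this set for which an assay on HEK293 cells for displacement of a labelled ligand from C-X-C chemokine receptor type 3 (Homo sapiens) (a higher number here means a weaker inhibitor, a lower number a stronger inhibitor), returns a number: in this assay compound 1 gives 3160 nM. Compound 2, `CN(CC1=CC[C@H]2C[C@@H]1C2(C)C)Cc1ccc(-c2cccc(C(F)(F)F)c2)cc1`, is recorded in this assay only as a limit, > 316 nM. Compound 3, `CN(CC1=CC[C@H]2C[C@@H]1C2(C)C)Cc1ccc(-c2ccc(C(F)(F)F)cc2)cc1`, likewise gives in this assay only the limit > 316 nM. The steps a step that the limit leaves unreadable from compound 1 to compound 2 and a step that the limit leaves unreadable from compound 1 to compound 3 therefore cannot be sized, a consequence of the limit of > 316 nM in this assay, at which 2 of the 3 values shown sit.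

Compound 4, `CN(CC1=CC[C@H]2C[C@@H]1C2(C)C)Cc1ccc(-c2cc(Cl)cc(Cl)c2)cc1`, differs from compound 1 by 3,5-dichlorophenyl in place of phenyl on an aromatic carbon. The measured steps that bear on this change are the two from compound 1 to compounds 2 and 3, in which a trifluoromethyl replaces hydrogen on an aromatic carbon of the same outer phenyl; neither of them yields a readable size, so they set no direction for the present change. No step in this set separates compound 1 from any compound by more than the usual scatter, and nothing shown suggests the outer ring tolerates or rejects halogen substitution.

Compound 4 is therefore estimated to lie in this assay at 2800 nM, between 800 nM and 9000 nM, an expected step of a 1.1-fold lower number from compound 1 to compound 4 (0.05 log units; within the scatter) that stays within the scatter around compound 1.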

Compound 4, inhibition constant: > 316 nM
Compound 4 gave a limit, no number; the forecaster's own chance of this, stated with the estimate: 55%; the middle value does not contradict the limit.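

Compound 4 is recorded in this assay only as a limit, > 316 nM, so no new step can be read between it and compound 1: the limit of > 316 nM in this assay, at which 3 of the 4 values shown sit.

The compounds shown leave open whether trifluoromethyl or chlorine on the outer phenyl of compound 1 changes the value in this assay at all, and in which direction.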